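Would Another Methoxy Lower the Number for Compound 3?

The source may report more compounds than this note shows. Statements on the series, on what has been measured and on what is new or still open speak of the compounds shown alone.

Measured in a functional assay on the whole organism (strain Sprague-Dawley) for inhibition, with Rattus norvegicus as the target, with a stated time of 10 min; on this read-out higher numbers stand for an effect only at larger amounts of compound and lower numbers for an effect already at smaller amounts:
- Compound 1 `COc1ccccc1-c1ncc(C(=O)O)c(=O)[nH]1`: 10 mg/kg
- Compound 2 `COc1ccc(OC)c(-c2ncc(C(=O)O)c(=O)[nH]2)c1`: 1 mg/kg
- Compound 3 `CCOC(=O)c1cnc(-c2ccccc2OC)[nH]c1=O`: 10 mg/kg

Compound 3, at 10 mg/kg, sits level with compound 1, and these two share the highest number of the three. Compound 2 has the lowest number, so on this read-out it shows an effect at the smallest dose. Compound 4 `CCOC(=O)c1cnc(-c2cc(OC)ccc2OC)[nH]c1=O` is compound 3 with one change, methoxy in place of hydrogen on an aromatic carbon, meta to a large group and para to a methoxy group.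

The same exchange has been measured once, giving a 10-fold lower number from compound 1 to compound 2 (1.00 log units; beyond the scatter). The other measured step, no change at the digits printed from compound 1 to compound 3 (within the scatter), swaps hydrogen for ethyl on an oxygen next to a carbonyl group, and the number stays put. These two steps suggest that the ethyl group may leave the methoxy gain intact, so a lower number is expected for compound 4. For the measured compounds named here, with only one pair as a guide, whether the full size carries over is unknown, so a somewhat smaller gain is the cautious expectation. The estimated step is a 5.0-fold lower number from compound 3 to compound 4 (0.70 log units; beyond the scatter). For compound 4 the expected value is 2 mg/kg, with an estimated range from 0.5 mg/kg to 10 mg/kg.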

Compound 4, dose for 50% inhibition: 5 mg/kg
The estimate for compound 4 lay 2.5-fold (0.40 log units) below the measured number, within the range that was stated.
By their numbers in this assay, from the lowest: compound 2; then compounds 4, 1 and 3 (each within the scatter of the next).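

In this assay, adding the methoxy to the core that carries the ethyl group gives a 2.0-fold lower number from compound 3 to compound 4 (0.30 log units; within the scatter), so on this core the change stays inside the usual scatter of repeated measurements. The earlier single pair could not show that the size of the methoxy step depends on the core it is made on: the same change on two cores in this assay, a 10-fold lower number (1.00 log units; beyond the scatter) from compound 1 to compound 2 and a 2.0-fold lower number (0.30 log units; within the scatter) from compound 3 to compound 4, 5.0-fold (0.70 log units) apart, beyond the scatter of two such steps Seen from the other side, the ethyl group left the number unchanged on the core of compound 1 but not on the core with the added methoxy, where the exchange gives a 5.0-fold higher number from compound 2 to compound 4 (0.70 log units; beyond the scatter), so the two changes cannot simply be treated as independent of each other: the same change on two cores in this assay, no change at the digits printed (within the scatter) from compound 1 to compound 3 and a 5.0-fold higher number (0.70 log units; beyond the scatter) from compound 2 to compound 4, 5.0-fold (0.70 log units) apart, beyond the scatter of two such steps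

Going by these compounds, all of this rests on a single set of four compounds, so it stays open whether the same dependence would appear with a methyl group or a longer chain in place of the ethyl. On these data alone, it also stays open whether an amine or a chlorine atom at the methoxy's place on the aromatic ring would follow the same pattern on either core.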